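This account rests on a few compounds, and the source may have more. Where it says the series, first, only, none or still open, it means among the compounds named here.

In an ADME assay on HepG2 2.2.15 cells (Homo sapiens) for cytotoxicity, read by MTT assay (on this read-out lower numbers stand for higher toxicity in this test and higher numbers for lower toxicity in this test), the measured compounds are:

Compound 1 `C=C1CC[C@@H]2[C@](C)(COC(=O)/C=C/c3ccccc3)[C@H](O)CC[C@@]2(C)[C@@H]1/C=C/C1=CCOC1=O`: 183000 nM
Compound 2 `C=C1CC[C@@H]2[C@](C)(COC(=O)/C=C/c3cc(OC)c(OC)c(OC)c3)[C@H](O)CC[C@@]2(C)[C@@H]1/C=C/C1=CCOC1=O`: > 1700000 nM (a limit of the assay, not a number)
Compound 3 `C=C1CC[C@@H]2[C@](C)(COC(=O)/C=C/c3ccccc3)[C@H](O)CC[C@@]2(C)[C@@H]1C/C=C1\C=COC1=O`: 271000 nM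

Compound 3 sits within the scatter of compound 1, as a 1.5-fold higher number from compound 1 to compound 3 (0.17 log units; within the scatter) shows. Within the data shown here, its number is therefore about as high as the only other exact number available. Compound 4 `C=C1CC[C@@H]2[C@](C)(COC(=O)/C=C/c3cc(OC)c(OC)c(OC)c3)[C@H](O)CC[C@@]2(C)[C@@H]1C/C=C1\C=COC1=O` differs from compound 3 in one place: 3,4,5-trimethoxyphenyl in place of phenyl on a double-bonded chain carbon bound to a double-bonded chain carbon.

The same swap has one measured example, which is an at least 9.2-fold higher number from compound 1 to compound 2 (0.96 log units; beyond the scatter). From the compounds shown here alone, that step lies beyond the scatter, but it is a single pair and it ends at a limit, so its full size is unknown. The other measured step, a 1.5-fold higher number from compound 1 to compound 3 (0.17 log units; within the scatter), suggests that compound 3 is a fair starting point in place of compound 1. A clear rise is therefore expected in this assay, meaning lower toxicity in this test, and the reading may stop at the limit of > 1700000 nM in this assay, at which 1 of the 3 values shown sits. The expected step is a 6.3-fold higher number from compound 3 to compound 4 (0.80 log units; beyond the scatter). The estimate for compound 4 is 1700000 nM, with an expected range from 600000 nM to 3000000 nM.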

Compound 4, half-maximal cytotoxic concentration: 325000 nM
The estimate for compound 4 lay 5.2-fold (0.72 log units) above the measured number; the measured number lies below the stated range.
By their numbers in this assay, from the lowest: compounds 1, 3 and 4 (each within the scatter of the next). At a limit, above all of these: compound 2.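

In this assay, 3,4,5-trimethoxyphenyl in place of phenyl on a double-bonded chain carbon bound to a double-bonded chain carbon does not act alike on the two cores; on the core of compound 3 it gives a 1.2-fold higher number from compound 3 to compound 4 (0.08 log units; within the scatter), and the gap between the two cores is clear: the same change on two cores in this assay, an at least 9.2-fold higher number (0.96 log units; beyond the scatter) from compound 1 to compound 2 and a 1.2-fold higher number (0.08 log units; within the scatter) from compound 3 to compound 4, at least 7.7-fold (0.88 log units) apart, beyond the scatter of two such steps. Read the other way, the exchange of the two five-membered non-aromatic ring groups on a saturated ring carbon also depends on its partner, with an at least 5.2-fold lower number from compound 2 to compound 4 (0.71 log units; beyond the scatter) once 3,4,5-trimethoxyphenyl is present, against a step within the scatter with phenyl: the same change on two cores in this assay, a 1.5-fold higher number (0.17 log units; within the scatter) from compound 1 to compound 3 and an at least 5.2-fold lower number (0.71 log units; beyond the scatter) from compound 2 to compound 4, at least 7.7-fold (0.88 log units) apart, beyond the scatter of two such steps. Compound 2 gives > 1700000 nM, which is a limit of the assay and not a number.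

Among these compounds, each change rests on only two pairs, so it remains open whether this dependence on the partner group extends to other groups on the aromatic ring, such as a hydroxyl or an amine in place of the methoxy groups. From the compounds shown here alone, it is equally open how an amide in place of the ester would behave on either core.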